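Exchanging the hydrazone aryl group on a triazine sulfonamide

The source may hold more compounds than are shown below. What is called first, only, known or untested is meant among the compounds shown, and "the series" means these compounds.

Measured so far:
Compound 1, `NS(=O)(=O)c1ccc(Nc2nc(N/N=C/c3ccc(C(F)(F)F)cc3)nc(Nc3ccccc3)n2)cc1`, gives 2790 nM in a functional assay on BT-549 cells (Homo sapiens) for inhibition, read by sulforhodamine B assay, with a stated time of 48 h; on this read-out lower numbers stand for stronger inhibition of growth and higher numbers for weaker inhibition of growth.
Compound 2, `Cc1nn(-c2ccccc2)cc1/C=N/Nc1nc(Nc2ccccc2)nc(Nc2ccc(S(N)(=O)=O)cc2)n1`, gives 1840 nM in this assay.

Among the measured compounds shown here, compound 2 stands at the lower of the two numbers, though its only neighbour, compound 1, sits within the scatter of it. Compound 3, `NS(=O)(=O)c1ccc(Nc2nc(N/N=C/c3ccccn3)nc(Nc3ccccc3)n2)cc1`, is compound 2 with pyridin-2-yl in place of 3-methyl-1-phenyl-1H-pyrazol-4-yl on a carbon with a double bond to nitrogen. For the measured compounds named here, the one measured step at this position, a 1.5-fold lower number from compound 1 to compound 2 (0.18 log units; within the scatter), stayed within the scatter, so a further exchange of the group here is expected to move the number little. The expected step in this assay is a 1.2-fold higher number from compound 2 to compound 3 (0.08 log units; within the scatter). Compound 3 is therefore estimated at 2200 nM, within 900 nM to 5500 nM.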

Compound 3, concentration for 50% growth inhibition: 890 nM
Compound 3: the middle estimate sits 2.5-fold (0.39 log units) above what was measured; measured number below the stated range.
By their numbers in this assay, from the lowest: compound 3; then compounds 2 and 1 (each within the scatter of the next).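

In this assay both a 2.1-fold lower number from compound 2 to compound 3 (0.32 log units; beyond the scatter) and a 3.1-fold lower number from compound 1 to compound 3 (0.50 log units; beyond the scatter) show that the group at this place can move the number beyond the scatter. The entering pyridin-2-yl has one ring and fewer heavy atoms than 3-methyl-1-phenyl-1H-pyrazol-4-yl, and it carries a ring nitrogen. Nothing available explains the lower number.

The compounds shown cannot separate the effect of ring size from that of the ring nitrogen. A plain phenyl group or an open-chain amine at this place remains an open comparison.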